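Series notes: amine change on the shared core

The source may hold more compounds than are shown below. What is called first, only, known or untested is meant among the compounds shown, and "the series" means these compounds.

Compound 1 `Cn1c(=O)c(S(=O)(=O)c2ccc(F)cc2[N+](=O)[O-])cc2cnc(Nc3ccc4[nH]ccc4c3)nc21` and compound 2 `Cc1ccc(S(=O)(=O)c2cc3cnc(Nc4ccc5[nH]ccc5c4)nc3n(C)c2=O)cc1` share a core and differ only in the aryl group on the sulfonyl sulfur. In a functional assay on K562 cells (Homo sapiens) for inhibition, read by trypan blue exclusion, with a stated time of 72 h (a higher number here means a weaker inhibitor, a lower number a stronger inhibitor), compound 1 gives 900 nM. In this assay compound 2 gives 750 nM. The one measured step, a 1.2-fold lower number from compound 1 to compound 2 (0.08 log units; within the scatter), lies within the scatter, so the two numbers show no order; compound 2 merely has the lower of the two numbers shown, with compound 1 the nearest. Compound 3 `Cc1ccc(S(=O)(=O)c2cc3cnc(Nc4cnc5c(c4)CC(=O)N5)nc3n(C)c2=O)cc1` keeps the 4-methylphenyl on the sulfonyl sulfur of compound 2 and alters the other end: a group of 10 heavy atoms (7 carbon, 2 nitrogen, 1 oxygen; one five-membered non-aromatic ring with 1 hetero atom, one six-membered aromatic ring with 1 hetero atom) in place of a group of 9 heavy atoms (8 carbon, 1 nitrogen; one five-membered aromatic ring with 1 hetero atom, one six-membered aromatic ring of carbon only), on a nitrogen on an aromatic ring. For the measured compounds named here, no measured step touches this position; the single step concerns the sulfonyl group and is not a guide here. With nothing bearing on the change, no shift beyond the scatter is expected in this assay in either direction, though the range must stay wide. Compound 3 is therefore expected to give 1000 nM in this assay, within 300 nM to 3500 nM. The expected step of a 1.3-fold higher number from compound 2 to compound 3 (0.12 log units; within the scatter) is small.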

Compound 3, half-maximal inhibitory concentration: 15000 nM
For compound 3 the middle estimate is 15-fold (1.18 log units) below the measured one; the whole stated range lies below it.
By their numbers in this assay, from the lowest: compounds 2 and 1 (each within the scatter of the next); then compound 3.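

In this assay this position matters, whereas the earlier step at the sulfonyl group stayed within the scatter: with the 4-methylphenyl on the sulfonyl sulfur held constant, the change on a nitrogen on an aromatic ring gives a 20-fold higher number from compound 2 to compound 3 (1.30 log units; beyond the scatter). The entering group differs from 1H-indol-5-yl in several features at once, including its five-membered non-aromatic ring, its six-membered aromatic ring with 1 hetero atom and its double bond outside aromatic rings, so this single step cannot assign the shift to any one of them. No available measurement accounts for the shift.

As far as these compounds go, it remains open whether the same shift appears with 4-fluoro-2-nitrophenyl on the sulfonyl sulfur. Also open, from the compounds shown here alone, is where a plain phenyl or a 1H-indazol-5-yl group at this position would fall relative to compound 2 and compound 3.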